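Chloro position swap on the ring nitrogen, hydroxyphenyl analogue

The source may report more compounds than this note shows. Statements on the series, on what has been measured and on what is new or still open speak of the compounds shown alone.

Compound 3 `Oc1ccc(C2=NN(c3ccc(Cl)cc3)C(c3cccc(Cl)c3)C2)cc1` stands highest of the three numbers in an assay on HEK293 cells for inhibition of protein kinase C zeta type (Homo sapiens), read by 33P incorporation, with a stated time of 40 min, tested at 20 uM, in the presence of a further agent that is not named here (on this read-out higher numbers stand for more inhibition at the one concentration tested (going by the name of the read-out) and lower numbers for less inhibition), with compound 3 giving 71.8%. Compound 2 `COc1ccc(C2=NN(c3ccc(Cl)cc3)C(c3cccc(Cl)c3)C2)cc1` gives 39%, and compound 1 `COc1ccc(C2=NN(c3cccc(Cl)c3)C(c3cccc(Cl)c3)C2)cc1` gives 25.3%; both gaps to compound 3 are beyond the scatter. The step of a number 32.8 percentage points higher from compound 2 to compound 3 (beyond the scatter) came with hydrogen in place of methyl on an oxygen on an aromatic ring. The step of a number 13.7 percentage points higher from compound 1 to compound 2 (beyond the scatter) came with 4-chlorophenyl in place of 3-chlorophenyl on an amine nitrogen in a ring.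

Compound 4 `Oc1ccc(C2=NN(c3cccc(Cl)c3)C(c3cccc(Cl)c3)C2)cc1` is not yet measured. It differs from compound 3 by 3-chlorophenyl in place of 4-chlorophenyl on an amine nitrogen in a ring. For the measured compounds named here, the one measured step that bears on this change is a number 13.7 percentage points higher from compound 1 to compound 2 (beyond the scatter), which ran the opposite way in the pair bearing methyl on the oxygen, and its size was modest. The expected step is therefore a number 13.8 percentage points lower from compound 3 to compound 4 (beyond the scatter), modest and downward, on the assumption that the change acts alike in the pair bearing hydrogen on the oxygen; none of the three measured compounds tests that assumption. The estimate for compound 4 in this assay is 58%, with a range of 42% to 74%.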

Compound 4, a percentage reported as inhibition, at one concentration (the size of the read-out at that concentration, not a potency): 85.7%
Compound 4: middle estimate off by 27.7 percentage points, on the low side; measured number above the stated range.
By their numbers in this assay, from the lowest: compound 1; then compound 2; then compound 3; then compound 4.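

The position of the chlorine on the aryl group on the ring nitrogen has no fixed direction of effect. With hydrogen on the oxygen, 3-chlorophenyl gives the higher number (a number 13.9 percentage points higher from compound 3 to compound 4 (beyond the scatter)), whereas with methyl on the oxygen, 4-chlorophenyl does, so the change reverses between the two pairs in this assay: (the same change on two cores in this assay, a number 13.7 percentage points higher (beyond the scatter) from compound 1 to compound 2 and a number 13.9 percentage points lower (beyond the scatter) from compound 4 to compound 3, 27.6 percentage points apart, beyond the scatter of two such steps). Hydrogen in place of methyl on the oxygen raises the number in both pairs, but the step with 3-chlorophenyl on the ring nitrogen (a number 60.4 percentage points higher from compound 1 to compound 4 (beyond the scatter)) is larger than the one with 4-chlorophenyl: (the same change on two cores in this assay, a number 32.8 percentage points higher (beyond the scatter) from compound 2 to compound 3 and a number 60.4 percentage points higher (beyond the scatter) from compound 1 to compound 4, 27.6 percentage points apart, beyond the scatter of two such steps). The two places therefore do not act independently across these four compounds, and the effect of the chlorine position has to be read together with the group on the oxygen.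

From the compounds shown here alone, whether the reversal extends beyond hydrogen and methyl on the oxygen stays open, for instance with an ethyl group or with a carboxylic acid or an amine in place of the hydroxyl. Also open, going by these compounds, are how a phenyl group without chlorine on the ring nitrogen compares and whether the order at this one concentration would hold for potency.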